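Growing the Amide Side Chain: From Isopropyl to Benzyl

This account rests on a few compounds, and the source may have more. Where it says the series, first, only, none or still open, it means among the compounds named here.

Measured compounds, all sharing the same core:
Compound 1, `CCC(=O)Nc1sc2c(c1C#N)CCCC2`, gives 12000 nM in a functional assay on RKE cells for antagonist activity at Vasoactive intestinal polypeptide receptor 1 (Rattus norvegicus), read by HTRF and cAMP accumulation, with stated times of 10 min and 30 min; a higher number here means a weaker inhibitor, a lower number a stronger inhibitor.
Compound 2, `CC(C)C(=O)Nc1sc2c(c1C#N)CCCC2`, gives 3400 nM in this assay.
Compound 3, `CC(C)CC(=O)Nc1sc2c(c1C#N)CCCC2`, gives 1900 nM in this assay.

Compound 3 has the lowest number of the three. Its nearest neighbour is compound 2, and the gap between them lies within the scatter, so the two cannot be ranked; compound 1 is clearly higher, as the steps of a 6.3-fold lower number from compound 1 to compound 3 (0.80 log units; beyond the scatter) and a 3.5-fold lower number from compound 1 to compound 2 (0.55 log units; beyond the scatter) show.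

Compound 4, `N#Cc1c(NC(=O)CCc2ccccc2)sc2c1CCCC2`, has not yet been measured. It differs from compound 3 in one place: benzyl in place of isopropyl on a saturated chain carbon bound to a carbonyl carbon. The acyl side chain on the amide thus becomes larger once more.

For the measured compounds named here, the steps that bear on this change are those in which the side chain grew: a 3.5-fold lower number from compound 1 to compound 2 (0.55 log units; beyond the scatter), a 6.3-fold lower number from compound 1 to compound 3 (0.80 log units; beyond the scatter) and a 1.8-fold lower number from compound 2 to compound 3 (0.25 log units; within the scatter). Each enlargement lowered the number or left it within the scatter. Going by the values given here, the present enlargement is larger than any of those, so a further modest lowering in this assay is expected, though the earlier steps give no direct guide to a benzyl group.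

Compound 4 is therefore estimated at 1000 nM, with a range from 300 nM to 4000 nM, corresponding to an expected step of a 1.9-fold lower number from compound 3 to compound 4 (0.28 log units; within the scatter).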

Compound 4, half-maximal inhibitory concentration: 290 nM
For compound 4 the middle estimate is 3.4-fold (0.54 log units) above the measured one; measured number below the stated range.
By their numbers in this assay, from the lowest: compound 4; then compounds 3 and 2 (each within the scatter of the next); then compound 1.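

In this assay, the change from isopropyl to benzyl on a saturated chain carbon bound to a carbonyl carbon gives a clear gain (a 6.6-fold lower number from compound 3 to compound 4 (0.82 log units; beyond the scatter)), whereas the previous enlargement stayed within the scatter (a 1.8-fold lower number from compound 2 to compound 3 (0.25 log units; within the scatter)). For the compounds shown here, the earlier compounds carry no ring on the side chain, so compound 4 is the first to show that this place tolerates a six-membered aromatic ring of carbon only, and that the number can keep falling as the side chain grows. Set against the small side chain of compound 1, the added phenyl completes a large overall change (a 41-fold lower number from compound 1 to compound 4 (1.62 log units; beyond the scatter)), and nothing measured here accounts for the size of this gain.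

The compounds shown do not separate the effect of the aromatic ring from that of the larger side chain, a question that cyclohexyl in place of the phenyl ring would address. Going by these compounds, how a longer chain carrying the phenyl ring, a phenyl ring bearing chlorine, or a pyridine ring would read in this assay also remains open.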